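This account rests on a few compounds, and the source may have more. Where it says the series, first, only, none or still open, it means among the compounds named here.

Measured compounds in a functional assay on HCT-116 cells (Homo sapiens) for inhibition, read by MTT assay, with a stated time of 48 h; on this read-out lower numbers stand for stronger inhibition and higher numbers for weaker inhibition:
Compound 1 `Fc1ccccc1CSc1nnc(-c2ccncc2)n1-c1ccccc1`: 12000 nM
Compound 2 `Brc1ccc(CSc2nnc(-c3ccncc3)n2-c2ccccc2)cc1`: 11100 nM
Compound 3 `O=C(CSc1nnc(-c2ccncc2)n1-c1ccccc1)N/N=C/c1ccc([N+](=O)[O-])cc1`: 10200 nM

Within this set compound 3 gives the lowest of the three numbers, but its gaps to compound 2 and to compound 1 are both within the scatter, so no order among the three compounds can be drawn from these numbers. Going by the values given here, the only measured step, a 1.1-fold lower number from compound 1 to compound 2 (0.03 log units; within the scatter), exchanges the aryl group on a saturated chain carbon bound to a sulfur and is itself within the scatter.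

Compound 4 `O=C(CSc1nnc(-c2ccncc2)n1-c1ccccc1)N/N=C/c1ccc(O)c(O)c1` differs from compound 3 as follows:
3,4-dihydroxyphenyl in place of 4-nitrophenyl on a carbon with a double bond to nitrogen
Among the compounds with values here, no measured step touches this place on a carbon with a double bond to nitrogen, so none bears directly on the change. Within the data shown here, the one step available, from compound 1 to compound 2 at the other peripheral position, was within the scatter, and compound 3, which carries the hydrazone chain instead of a benzyl group, also sits within the scatter of both. Across the three compounds, peripheral exchanges have left this assay flat. The expected step is therefore none beyond the scatter, a 1.0-fold lower number from compound 3 to compound 4 (0.01 log units; within the scatter). Compound 4 is estimated at 10000 nM, in the range 3500 nM to 30000 nM.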

Compound 4, half-maximal inhibitory concentration: 14700 nM
For compound 4 the middle estimate is 1.5-fold (0.17 log units) below the measured one, within the range that was stated.
By their numbers in this assay, from the lowest: compounds 3, 2, 1 and 4 (each within the scatter of the next).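

In this assay, the place on a carbon with a double bond to nitrogen now has a measured step of its own: exchanging 4-nitrophenyl for 3,4-dihydroxyphenyl gives a 1.4-fold higher number from compound 3 to compound 4 (0.16 log units; within the scatter). This exchange takes out a group with 0 hydrogen-bond donors and brings in one with 2 hydrogen-bond donors, yet the two numbers stay within the scatter of each other, so this difference in donor count does not separate compound 3 from compound 4 in this read-out. No measurement at hand explains the step or links it to any property of either group.

On these data alone, with only these two aryl groups on this carbon, it remains open whether a 4-aminophenyl or a 4-carboxyphenyl group, or a longer chain carrying the ring, would move the number beyond the scatter. As far as these compounds go, it also remains open whether the 3,4-dihydroxyphenyl and 4-nitrophenyl groups would stay within the scatter of each other on a cell line other than the one used here.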